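Swapping the aryl on the piperazine of compound 2

This account rests on a few compounds, and the source may have more. Where it says the series, first, only, none or still open, it means among the compounds named here.

compound 1, `CCc1nc(-c2ccc(OC)cc2)c(C(=O)N2CCN(c3cccc(Cl)c3)CC2)o1`: in a functional assay on HL-60 cells (Homo sapiens) for inhibition, read by MTT assay, with a stated time of 72 h (a higher number here means a weaker inhibitor, a lower number a stronger inhibitor), compound 1 gives a limit, > 1000 nM.
compound 2, `Cc1nc(-c2ccccc2)c(C(=O)N2CCN(c3c(C)cccc3C)CC2)o1`: compound 2 gives 146 nM.
compound 3, `CCc1nc(-c2ccccc2F)c(C(=O)N2CCN(c3cccc(Cl)c3)CC2)o1`: compound 3 gives 139 nM.

Compound 2 has the highest of the two numbers, but compound 3 sits within the scatter of it. For the measured compounds named here, the only measured step, an at least 7.1-fold lower number from compound 1 to compound 3 (0.85 log units; beyond the scatter), concerns the aryl on the aromatic carbon; for compound 1 this is a limit (the limit of > 1000 nM in this assay, at which 1 of the 3 values shown sits). Compound 4, `CCOc1cccc(N2CCN(C(=O)c3oc(C)nc3-c3ccccc3)CC2)c1`, instead changes the aryl on the ring nitrogen: 3-ethoxyphenyl in place of 2,6-dimethylphenyl on an amine nitrogen in a ring. Going by the values given here, no measured step touches that position, so the account leans on compound 2 alone. Compound 4 is expected to stay near compound 2, with a step of a 1.7-fold higher number from compound 2 to compound 4 (0.23 log units; within the scatter) inside or just beyond the scatter. The estimate for compound 4 is 250 nM, between 80 nM and 900 nM.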

Compound 4, half-maximal inhibitory concentration: 151 nM
Compound 4: the middle estimate sits 1.7-fold (0.22 log units) above what was measured; low and high end bracket the measured number.
By their numbers in this assay, from the lowest: compounds 3, 2 and 4 (each within the scatter of the next). At a limit, above all of these: compound 1.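

For the compounds shown here, the first measured step at the aryl on the amine nitrogen in a ring reads, in this assay, a 1.0-fold higher number from compound 2 to compound 4 (0.01 log units; within the scatter). The two aryl groups therefore cannot be told apart here, although 3-ethoxyphenyl brings a hydrogen-bond acceptor that 2,6-dimethylphenyl lacks. Nothing measured here explains this result.

The compounds shown leave open whether this position would accept an aryl bearing a carboxylic acid or an amine. They also leave open whether a longer chain in place of the ethoxy group would give a similar number.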